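Pyridin-3-yl for Phenyl on the Benzyloxy Arm

This account rests on a few compounds, and the source may have more. Where it says the series, first, only, none or still open, it means among the compounds named here.

Compound 1 `O=c1cc(N2CCNCC2)c2ccc(OCc3ccccc3)cc2o1`: 16300 nM in a functional assay on a cell-free system (plasma, Homo sapiens) for inhibition, with Plasma (Rattus norvegicus) as the target; a higher number here means a weaker inhibitor, a lower number a stronger inhibitor
Compound 2 `Cc1c(OCc2ccccc2)ccc2c(N3CCNCC3)cc(=O)oc12`: 1900 nM in this assay

Among the compounds with values here, compound 1 gives the highest of the two numbers so far; its only neighbour shows an 8.6-fold lower number from compound 1 to compound 2 (0.93 log units; beyond the scatter). Compound 3 `O=c1cc(N2CCNCC2)c2ccc(OCc3cccnc3)cc2o1` differs from compound 1 by pyridin-3-yl in place of phenyl on a saturated chain carbon bound to an oxygen on an aromatic ring. Within the data shown here, no measured step bears on this change: the one step known concerns methyl in place of hydrogen on an aromatic carbon, a different place. With nothing to build on, no step beyond the scatter is expected in this assay. Compound 3 is therefore estimated at 16000 nM, with a range from 5000 nM to 50000 nM, which would mean a 1.0-fold lower number from compound 1 to compound 3 (0.01 log units; within the scatter).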

Compound 3, half-maximal inhibitory concentration: 21300 nM
Beside the measured number, compound 3's estimate is 1.3-fold (0.12 log units) below it; the measured number falls inside the stated range.
By their numbers in this assay, from the lowest: compound 2; then compounds 1 and 3 (each within the scatter of the next).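

On the benzyloxy arm, pyridin-3-yl in place of phenyl gives a 1.3-fold higher number from compound 1 to compound 3 (0.12 log units; within the scatter) in this assay, so compound 1 and compound 3 cannot be told apart here. Within the data shown here, this is the first reading on the ring of this arm, which the earlier compounds left untouched, and that ring takes a ring nitrogen with no step beyond the scatter. No measurement at hand speaks to why. Still open, as far as these compounds go, is whether pyridin-4-yl, cyclohexyl or a phenyl carrying a carboxylic acid would read the same on this arm. Also open, from the compounds shown here alone, is what the methyl of compound 2 and pyridin-3-yl would give in one compound.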